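A fluoro on the phenyl ring of compound 3

The source may report more compounds than this note shows. Statements on the series, on what has been measured and on what is new or still open speak of the compounds shown alone.

Among the compounds with values here, in a toxicity assay on Huh-7 cells (Homo sapiens) for cytotoxicity, read by CCK-8 assay, with a stated time of 24 h (on this read-out lower numbers stand for higher toxicity in this test and higher numbers for lower toxicity in this test), compound 3 `O=c1cc(-c2ccccc2)oc2c(-c3ccccc3)c(O)c(O)c(O)c12` gives 86300 nM, the only actual number among the three compounds measured. Compound 1 `O=c1cc(-c2ccccc2)oc2c(-c3cccc(F)c3)c(O)c(O)c(O)c12` returns a limit, > 100000 nM, and not a number. Compound 2 `Cc1ccc(-c2c(O)c(O)c(O)c3c(=O)cc(-c4ccccc4)oc23)cc1` also returns a limit, > 100000 nM. Compound 4 `O=c1cc(-c2ccccc2)oc2c(-c3ccc(F)cc3)c(O)c(O)c(O)c12` differs from compound 3 by fluoro in place of hydrogen on an aromatic carbon, with fluoro in place of hydrogen on an aromatic carbon, so that phenyl becomes 4-fluorophenyl. The closest evidence is the other fluoro case, where hydrogen in place of fluoro gave an at least 1.1-fold lower number from compound 1 to compound 3 (0.06 log units; that floor lies within the scatter). Hydrogen in place of methyl gave an at least 1.1-fold lower number from compound 2 to compound 3 (0.06 log units; that floor lies within the scatter). Neither step shows a change beyond the scatter, and any reading must reckon with the limit of > 100000 nM in this assay, at which 2 of the 3 values shown sit. On the strength of an at least 1.1-fold lower number from compound 1 to compound 3 (0.06 log units; that floor lies within the scatter), a small rise in the number, no larger than the scatter, is expected, and the estimate amounts to a 1.2-fold higher number from compound 3 to compound 4 (0.09 log units; within the scatter). Compound 4 is estimated at 105000 nM, with an expected range from 55000 nM to 200000 nM.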

Compound 4, half-maximal cytotoxic concentration: > 100000 nM
Compound 4: a limit, no number; the forecaster's own chance of this, stated with the estimate: 55%; the middle value lies beyond the limit too.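

In this assay compound 4 gives > 100000 nM, which is a limit and not a number. What is new is the result for fluoro on the aromatic carbon para to a large group: it gives an at least 1.1-fold higher number from compound 3 to compound 4 (0.06 log units; that floor lies within the scatter), so this change, like the 3-fluorophenyl of compound 1, shows no step beyond the scatter, though a floor of this kind does not exclude a larger one. The steps from compound 1 and from compound 2 to compound 4 cannot be read, and one feature bears on all these comparisons: the limit of > 100000 nM in this assay, at which 3 of the 4 values shown sit.

As far as these compounds go, how far fluoro at this position truly moves the number remains open, and so does any difference between 4-fluorophenyl and 3-fluorophenyl. The compounds shown also leave open how an amine or a carboxylic acid on this phenyl ring would read in this assay.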